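Swapping Methoxy for Phenyl on a Terpene Styrene

The compounds below may be only part of what the source reports. "The series", "measured", "known", "first", "only" and "open" are said of these compounds alone.

Compound 1 `C=C[C@@](C)(/C=C/c1ccc(OC)cc1)CCC=C(C)C` was tested in an ADME assay on BJ cells (Homo sapiens) for cytotoxicity, with a stated time of 72 h; on this read-out higher numbers stand for an effect only at larger amounts of compound and lower numbers for an effect already at smaller amounts. In this assay compound 1 gives > 36600 nM, which is a limit of the assay rather than a number. Compound 2 `C=C[C@@](C)(/C=C/c1ccc(O)cc1)CCC1OC1(C)C` also reaches only a limit, at > 36600 nM. Compound 3 `COc1ccc(/C=C/[C@@](C)(/C=C/c2ccc(O)c(/C=C/C(=O)OCc3ccccc3)c2)CCC=C(C)C)cc1` likewise gives a limit, > 36600 nM. So compound 1 sits where every known compound sits, at the limit of > 36600 nM in this assay, at which 3 of the 3 values shown sit, with no number of its own. Among the measured compounds shown here, no step between measured compounds exists here. The change to compound 4 `C=C[C@@](C)(/C=C/c1ccc(-c2ccccc2)cc1)CCC=C(C)C` is phenyl in place of methoxy on an aromatic carbon. For the measured compounds named here, with no measured step to lean on, the step that the limit leaves unreadable from compound 1 to compound 4 is expected to be none beyond the scatter. Compound 4 is therefore estimated at 40000 nM, within 15000 nM to 100000 nM, quite possibly again only as a limit.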

Compound 4, half-maximal effective concentration: > 36600 nM
Compound 4: a limit, no number; the forecaster's own chance of this, stated with the estimate: 70%; the middle value is on the limit's open side.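

Among the compounds shown here, no step from compound 1 to compound 4 can be read, since each gives only a limit of the assay and not a number. The compounds shown leave open at what concentration any of them would have an effect in this assay and whether phenyl in place of methoxy changes it.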